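The source may report more compounds than this note shows. Statements on the series, on what has been measured and on what is new or still open speak of the compounds shown alone.

Compound 3 `CC(C)(N)CCCN(C[C@H]1Cc2ccccc2CN1)[C@H]1CCCc2cccnc21` gives 24.6 nM in a functional assay on cells for antagonist activity at C-X-C chemokine receptor type 4 (Homo sapiens), read by fluorescence and calcium flux, with stated times of 25 min and 90 s; on this read-out higher numbers stand for weaker inhibition and lower numbers for stronger inhibition. Among the three measured compounds it stands second highest: compound 1 `c1cncc(CNCCCCN(C[C@H]2Cc3ccccc3CN2)[C@H]2CCCc3cccnc32)c1` gives 15.3 nM, a gap within the scatter, while compound 2 `c1ccc2c(c1)CN[C@@H](CN(CCCCNC1CCNCC1)[C@H]1CCCc3cccnc31)C2` gives 63.4 nM, and a 2.6-fold lower number from compound 2 to compound 3 (0.41 log units; beyond the scatter) lies beyond the scatter. Compound 4 `C(=C/CN(C[C@H]1Cc2ccccc2CN1)[C@H]1CCCc2cccnc21)\CNCc1ccccn1` has not yet been measured; it differs from compound 3 by a group of 11 heavy atoms (9 carbon, 2 nitrogen; one six-membered aromatic ring with 1 hetero atom) in place of a group of 6 heavy atoms (5 carbon, 1 nitrogen; no ring), on a saturated chain carbon bound to an amine nitrogen. The measured step that bears on this is a 1.6-fold higher number from compound 1 to compound 3 (0.21 log units; within the scatter), in which a (((pyridin-3-yl)methyl)amino)methyl chain end was exchanged for 1-amino-1-methylethyl without a change beyond the scatter. Compound 4 brings a chain of that kind back, now carrying a double bond and a pyridine ring. For compound 4 a step no larger than the scatter is therefore expected: a 1.1-fold lower number from compound 3 to compound 4 (0.05 log units; within the scatter). Compound 4 is estimated at 22 nM, with a range from 7 nM to 70 nM.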

Compound 4, half-maximal inhibitory concentration: 58.3 nM
For compound 4 the middle estimate is 2.7-fold (0.42 log units) below the measured one; measured number inside the range.
By their numbers in this assay, from the lowest: compounds 1 and 3 (each within the scatter of the next); then compounds 4 and 2 (each within the scatter of the next).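

The chain in compound 4 is not tolerated as well as the earlier chain ends suggested, with a 2.4-fold higher number from compound 3 to compound 4 (0.37 log units; beyond the scatter). Even a chain with the same heavy-atom count and a pyridine ring gives a different result, with a 3.8-fold higher number from compound 1 to compound 4 (0.58 log units; beyond the scatter), so chain size and the presence of that ring do not settle the outcome at this position. The piperidine-bearing chain remains level, with a 1.1-fold lower number from compound 2 to compound 4 (0.04 log units; within the scatter).

No measured evidence explains these differences. Going by these compounds, whether the double bond contributes stays open, as does the effect of a chain ending in a morpholine ring or a carboxylic acid.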